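The source may hold more compounds than are shown below. What is called first, only, known or untested is meant among the compounds shown, and "the series" means these compounds.

Measured in a functional assay on MCF7 cells (Homo sapiens) for antiproliferative activity, read by MTT assay, with a stated time of 48 h; a higher number here means a weaker inhibitor, a lower number a stronger inhibitor:

compound 1, `Cc1cccc(-n2nncc2CN2C(=O)C3(C(C#N)=C(N)Oc4c3c3nc5ccccc5nc3c3ccccc43)c3ccccc32)c1`, gives > 50000 nM, which is a limit of the assay and not a number.
compound 2, `Cc1ccc(-n2nncc2CN2C(=O)C3(C(C#N)=C(N)Oc4c3c3nc5ccccc5nc3c3ccccc43)c3ccccc32)cc1C`, gives > 50000 nM, again a limit of the assay.
compound 3, `N#CC1=C(N)Oc2c(N)cc3nc4ccccc4nc3c2C12C(=O)N(Cc1cnnn1-c1ccc(Cl)cc1)c1ccccc12`, gives > 50000 nM, also a limit of the assay.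

Compound 3 thus stands where the whole set stands: the limit of > 50000 nM in this assay, at which 3 of the 3 values shown sit. No number is known for it, only that it lies past the limit. Among the measured compounds shown here, the one step between measured compounds, a step that the two limits leave unreadable from compound 1 to compound 2, runs from one limit to another and gives no readable size.

Compound 4, `CCOc1ccc(-n2nncc2CN2C(=O)C3(C(C#N)=C(N)Oc4c(N)cc5nc6ccccc6nc5c43)c3ccccc32)cc1`, is unmeasured. It differs from compound 3 by ethoxy in place of chloro on an aromatic carbon. No measured step concerns an ethoxy group or a chloro group, so nothing among the shown steps bears directly on this change, and the only measured step is itself unreadable. The expectation for compound 4 in this assay therefore rests on the fact that every measured member sits at the limit, and the step from compound 3 to compound 4 is expected to be a step that the limit leaves unreadable from compound 3 to compound 4, most probably again unreadable. Compound 4 is estimated at 60000 nM, with a range from 15000 nM to 250000 nM, and a limit rather than a number is the likeliest outcome.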

Compound 4, half-maximal inhibitory concentration: 26800 nM
The estimate for compound 4 lay 2.2-fold (0.35 log units) above the measured number; measured number inside the range.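

In this assay, among the compounds shown here, compound 4 gives 26800 nM, the first readable number, which shows that activity can be measured in this assay with a substituent at this position, on an aromatic carbon para to a large group. As far as these compounds go, the change from 4-chlorophenyl to 4-ethoxyphenyl is an at least 1.8-fold lower number from compound 3 to compound 4 (0.27 log units; that floor lies within the scatter); the direction is readable, but the printed floor lies within the scatter, so this step alone does not establish a real gain, and its full size stays unknown. The step from compound 1 to compound 2 cannot be read, so this is the only change in the series with any readable direction, and compound 4 is the only member off the shared ceiling: the limit of > 50000 nM in this assay, at which 3 of the 4 values shown sit.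

The compounds shown leave open whether the lower number belongs to ethoxy itself or would also appear with methoxy, a longer chain such as butoxy, or an amine on the same carbon. They also leave open whether the same change would give a number on the core of compound 1, which differs from compound 4 in more than one place.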